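The source may hold more compounds than are shown below. What is called first, only, known or untested is meant among the compounds shown, and "the series" means these compounds.

Compound 1 `O=S(=O)(c1ccc(F)c(F)c1)c1cnc2c(F)cccc2c1-c1ccc(Cl)cc1` and compound 2 `O=S(=O)(c1ccc(F)c(F)c1)c1cnc2c(F)cccc2c1-c1ccccc1F` share a core and differ only in the ring that hangs from it. In an ADME assay on microsomes from liver (Homo sapiens) for metabolic stability, tested at 2.5 uM (on this read-out lower numbers stand for slow clearance and higher numbers for fast clearance), compound 1 gives 0.28 mL/min, while compound 2 gives 1.39 mL/min. Of the two numbers at hand, compound 1 stands lowest, and the one shown step, a 5.0-fold higher number from compound 1 to compound 2 (0.70 log units; beyond the scatter), lies beyond the scatter and comes from swapping that hanging ring.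

Among the measured compounds shown here, compound 3 `O=S(=O)(c1cccc(F)c1)c1cnc2c(F)cccc2c1-c1ccc(Cl)cc1` instead alters the ring attached to the sulfonyl group. hydrogen in place of fluoro on an aromatic carbon Nothing measured so far touches that ring, so the step from compound 1 to compound 2 speaks to a different part of the molecule and offers no direct guide. With no comparable change in hand, the expectation rests on the small size of the change alone: a shift within the scatter, or a slightly higher number, is expected, written as a 1.6-fold higher number from compound 1 to compound 3 (0.21 log units; within the scatter). For compound 3 in this assay the estimate is therefore 0.45 mL/min, with a range from 0.2 mL/min to 1 mL/min.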

Compound 3, intrinsic clearance in a liver preparation (reported as CLH), per the amount of preparation that the assay uses: 0.62 mL/min
Estimate against measurement, compound 3: 1.4-fold (0.14 log units) below, within the range that was stated.
By their numbers in this assay, from the lowest: compound 1; then compound 3; then compound 2.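

Going from 3,4-difluorophenyl to 3-fluorophenyl replaces a single fluoro with hydrogen, yet in this assay it gives a 2.2-fold higher number from compound 1 to compound 3 (0.35 log units; beyond the scatter), so this position, para to a large group on the ring attached to the sulfonyl group, does register in the read-out. Changes at two separate parts of the molecule have now moved the number, and in both cases the move away from compound 1 is upward, which leaves compound 1 lowest of the three compounds. What lies behind the rise at this position remains unexplained, as no supporting measurement bears on it.

As far as these compounds go, it remains open whether fluoro is special here or whether other groups at this position, such as a methoxy group or an amine, would give a number closer to that of compound 1 or to that of compound 3. From the compounds shown here alone, it is also open whether removing this fluoro would have a similar effect alongside the 2-fluorophenyl ring of compound 2, as the two changes are seen here only separately.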